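The compounds below may be only part of what the source reports. "The series", "measured", "known", "first", "only" and "open" are said of these compounds alone.

Measured in a functional assay on the whole organism with Rattus norvegicus as the target; on this read-out lower numbers stand for an effect already at smaller amounts and higher numbers for an effect only at larger amounts of compound:
compound 1, `CC1CCC(=NNc2ccccc2)c2ncc(C(=O)O)c(=O)n21`: 1.2 umol/kg.
compound 2, `Cc1cc(C)cc(NN=C2CCC(C)n3c2ncc(C(=O)O)c3=O)c1`: > 320 umol/kg.
compound 3, `Cc1cccc(C)c1NN=C1CCC(C)n2c1ncc(C(=O)O)c2=O`: 320 umol/kg.

The entry of compound 2 is a limit of this read-out, not a number (the limit of > 320 umol/kg in this assay, at which 1 of the 3 values shown sits). Compound 3 stands at the higher of the two numbers; the nearest is compound 1, with a 270-fold higher number from compound 1 to compound 3 (2.43 log units; beyond the scatter). Compound 4, `CC1CCC(=NNc2ccc(Cl)cc2Cl)c2ncc(C(=O)O)c(=O)n21`, differs from compound 3 in one place: 2,4-dichlorophenyl in place of 2,6-dimethylphenyl on an amine nitrogen. Within the data shown here, no measured step exchanges one substituted phenyl for another with a readable size, since a number no higher from compound 2 to compound 3 (the limit leaves the size open) leaves the size open. Among the measured compounds shown here, the steps that bear on it are a 270-fold higher number from compound 1 to compound 3 (2.43 log units; beyond the scatter) and an at least 260-fold higher number from compound 1 to compound 2 (2.42 log units; beyond the scatter), both large and both in the same direction away from plain phenyl. Compound 4, still carrying a substituted phenyl, is expected to stay well apart from compound 1, and the step of an 11-fold lower number from compound 3 to compound 4 (1.03 log units; beyond the scatter) is expected downward but of uncertain size. Compound 4 is estimated at 30 umol/kg, range 3 umol/kg to 320 umol/kg.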

Compound 4, dose for 50% inhibition: > 100 umol/kg
Compound 4: a limit, no number; the forecaster's own chance of this, stated with the estimate: 20%; middle value at least 3.3-fold (0.52 log units) from the limit.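

In this assay compound 4 gives > 100 umol/kg, which is a limit and not a number. The step away from plain phenyl on the amine nitrogen is again large, with an at least 83-fold higher number from compound 1 to compound 4 (1.92 log units; beyond the scatter), so it is not confined to the two dimethylphenyl groups, and no substituted phenyl shown goes against this. The steps to compound 4 from compound 2 and from compound 3 cannot be read, so these three substituted phenyls cannot be ordered.

Still open, on these data alone, is whether a phenyl carrying a single fluorine or a single methoxy stays close to compound 1 or moves as far away as these three.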